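Solubility notes: carbonyl inserted into a stilbene linker

A few compounds are considered here, and "the series" means these few. Any claim that something is new, unique, unknown or untested is made for them only; others in the source may bear on it.

Three compounds of the series have numbers in a physicochemical assay for solubility, read by spectrophotometry, in simulated intestinal fluid, at pH 5; a lower number here means a less soluble compound, a higher number a more soluble compound. Compound 1 `CC(C)(CCCOc1ccc(/C=C/c2ccccc2)cc1)C(=O)O` gives 7.39 ug/mL, compound 2 `COc1ccc(/C=C/c2ccc(OCCCC(C)(C)C(=O)O)cc2)cc1` gives 6.23 ug/mL, and compound 3 `CC(C)(Oc1ccc(CCCOc2ccc(/C=C/c3ccccc3)cc2)cc1)C(=O)O` gives 13.9 ug/mL. Among the measured compounds shown here, the only single-point step measured, a 1.2-fold lower number from compound 1 to compound 2 (0.07 log units; within the scatter), is within the scatter. Compound 3 sits within the scatter of compound 1 and beyond the scatter of compound 2. Compound 4 `CC(C)(Oc1ccc(CCCOc2ccc(C(=O)/C=C/c3ccccc3)cc2)cc1)C(=O)O` differs from compound 3 by (2-phenylethenyl)carbonyl in place of 2-phenylethenyl on an aromatic carbon. For the measured compounds named here, no measured step covers this kind of change; the one step that exists, a 1.2-fold lower number from compound 1 to compound 2 (0.07 log units; within the scatter), was small, so nothing here argues for a shift beyond the scatter in this assay. The number for compound 4 is therefore estimated near that of compound 3, at 11 ug/mL, with a range of 4 ug/mL to 30 ug/mL. The step of a 1.3-fold lower number from compound 3 to compound 4 (0.10 log units; within the scatter) is the expected consequence.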

Compound 4, solubility: 17.8 ug/mL
Compound 4: middle estimate off by 1.6-fold (0.21 log units), on the low side; the measured number falls inside the stated range.
By their numbers in this assay, from the lowest: compounds 2, 1, 3 and 4 (each within the scatter of the next, the first and the last beyond it).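

In this assay, among the compounds shown here, (2-phenylethenyl)carbonyl in place of 2-phenylethenyl on an aromatic carbon, para to a large group, gives a 1.3-fold higher number from compound 3 to compound 4 (0.11 log units; within the scatter) and so adds a first reading at this position. The added carbonyl and its hydrogen-bond acceptor leave the number within the scatter in this series. Nothing available bears on the reason for this result.
On these data alone, whether an amine, a morpholine ring or a longer chain at this position would move the number beyond the scatter stays open. So does whether the same change would behave alike on the core of compound 1.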